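Benzylamine aryl swap on the benzyloxymethyl diaminopyrimidine series

This account rests on a few compounds, and the source may have more. Where it says the series, first, only, none or still open, it means among the compounds named here.

Measured compounds in an in vitro assay on CHOK cells for displacement of a labelled ligand from growth hormone secretagogue receptor type 1 (Homo sapiens); a higher number here means a weaker inhibitor, a lower number a stronger inhibitor:
compound 1 `CCc1nc(N)nc(N)c1-c1ccc(NCc2cc(F)c(S(C)(=O)=O)c(F)c2)cc1`, 2.4 nM
compound 2 `CCc1nc(N)nc(N)c1-c1ccc(NCc2ccc([N+](=O)[O-])cc2)cc1`, 11 nM
compound 3 `Nc1nc(N)c(-c2ccc(NCc3ccc([N+](=O)[O-])cc3)cc2)c(COCc2ccccc2)n1`, 0.2 nM

Compound 3 stands lowest of the three numbers in this assay ; its nearest neighbour is compound 1 and its furthest is compound 2, both gaps beyond the scatter. Within the data shown here, the only single-place step recorded is a 55-fold lower number from compound 2 to compound 3 (1.74 log units; beyond the scatter), which concerns the substituent on the core and not the benzylamine aryl.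

Compound 4 `Nc1nc(N)c(-c2ccc(NCc3cnc4ccccc4c3)cc2)c(COCc2ccccc2)n1` differs from compound 3 by quinolin-3-yl in place of 4-nitrophenyl on a saturated chain carbon bound to a nitrogen on an aromatic ring. Among the measured compounds shown here, no measured step covers a change at this position; compounds 1 and 2, which carry different aryl groups there, give numbers that differ by less than the step from compound 2 to compound 3, so the position appears less decisive than the core substituent. With the benzyloxy group retained, compound 4 is expected to remain a strong inhibitor, with a step of a 3.0-fold higher number from compound 3 to compound 4 (0.48 log units; beyond the scatter) toward a somewhat higher number. The estimate for compound 4 is 0.6 nM, range 0.15 nM to 3 nM.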

Compound 4, half-maximal inhibitory concentration: 130 nM
For compound 4 the middle estimate is 220-fold (2.34 log units) below the measured one; the whole stated range lies below it.
By their numbers in this assay, from the lowest: compound 3; then compound 1; then compound 2; then compound 4.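

In this assay, the aryl group on the saturated chain carbon bound to a nitrogen on an aromatic ring proves decisive: with benzyloxy retained, the change gives a 650-fold higher number from compound 3 to compound 4 (2.81 log units; beyond the scatter). This step is larger than a 55-fold lower number from compound 2 to compound 3 (1.74 log units; beyond the scatter), so the benzyloxy group does not secure a low number on its own, and its effect has to be read together with the aryl group it is paired with. Nothing available bears on why this aryl change has so large an effect.

The change removes the nitro group and brings in a second aromatic ring in one step, so the two cannot be separated here. Going by these compounds, a plain phenyl or a 4-aminophenyl group at this place would tell them apart, and how the aryl group of compound 1 behaves alongside benzyloxy remains open.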